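Changing the nitrogen substituent of compound 3

The source may report more compounds than this note shows. Statements on the series, on what has been measured and on what is new or still open speak of the compounds shown alone.

Measured in a functional assay on HOS-TE85 cells (Homo sapiens) for inhibition, read by CCK-8 assay, with a stated time of 72 h; on this read-out lower numbers stand for stronger inhibition and higher numbers for weaker inhibition:
Compound 1 `COc1ccc(F)cc1N1C(=O)CSC1c1cccc(C(=O)NCCCCn2cccn2)c1`: 97.3 nM
Compound 2 `O=C(NCCCCn1cccn1)c1cccc(C2SCC(=O)N2c2cc(Br)ccn2)c1`: 105 nM
Compound 3 `O=C(NCCCCn1cccn1)c1cccc(C2SCC(=O)N2c2ccccn2)c1`: 60.3 nM

In this assay compound 3 gives 60.3 nM. The data show a 1.6-fold lower number from compound 1 to compound 3 (0.21 log units; within the scatter) and a 1.7-fold lower number from compound 2 to compound 3 (0.24 log units; within the scatter), so these three compounds cannot be put in order.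

The next compound, compound 4 `CCOC(=O)c1sc(N2C(=O)CSC2c2cccc(C(=O)NCCCCn3cccn3)c2)nc1C`, differs from compound 3 in one group: 5-(ethoxycarbonyl)-4-methyl-1,3-thiazol-2-yl in place of pyridin-2-yl on an amide-type nitrogen in a ring. Its 5-(ethoxycarbonyl)-4-methyl-1,3-thiazol-2-yl takes the place of pyridin-2-yl on an amide-type nitrogen in a ring.

Changes at this same place have so far moved the number little, as seen in a 1.1-fold higher number from compound 1 to compound 2 (0.03 log units; within the scatter) and the two steps above. Among the compounds with values here, none of the measured compounds carries a five-membered aromatic ring here, so the guidance is indirect and the range must stay wide. The expected change is small and slightly upward, within the scatter: a 1.4-fold higher number from compound 3 to compound 4 (0.15 log units; within the scatter).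

For compound 4 the estimated value is 85 nM, with an expected range from 25 nM to 290 nM.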

Compound 4, half-maximal inhibitory concentration: 430 nM
The estimate for compound 4 lay 5.1-fold (0.70 log units) below the measured number; the whole stated range lies below it.
By their numbers in this assay, from the lowest: compounds 3, 1 and 2 (each within the scatter of the next); then compound 4.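

Until now every change on the amide-type nitrogen in a ring stayed within the scatter, so this place seemed to accept quite different aromatic groups. Within the data shown here, the 5-(ethoxycarbonyl)-4-methyl-1,3-thiazol-2-yl group is the first to move the number beyond the scatter, and it does so against all three earlier compounds in this assay (a 7.1-fold higher number from compound 3 to compound 4 (0.85 log units; beyond the scatter); a 4.1-fold higher number from compound 2 to compound 4 (0.61 log units; beyond the scatter); a 4.4-fold higher number from compound 1 to compound 4 (0.65 log units; beyond the scatter)), which shows that inhibition in these cells does depend on the group at this place. No measurement at hand says why the number rises.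

This single change swaps the six-membered ring for a five-membered one and also brings in the methyl and ethoxycarbonyl groups, so the compounds shown cannot say which part matters. A plain 1,3-thiazol-2-yl, or the same ring bearing a carboxylic acid instead of the ethyl ester, would help separate these parts.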